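Benzyl to 2-methylphenoxy: a change at the outer ring

The source may hold more compounds than are shown below. What is called first, only, known or untested is meant among the compounds shown, and "the series" means these compounds.

Three compounds have been measured in an assay on cells for agonist activity at probable G-protein coupled receptor 34 (Mus musculus), with a stated time of 1 h; on this read-out higher numbers stand for larger maximal responses and lower numbers for smaller maximal responses:

Compound 1, `CCCCCCCCCCCOc1ccccc1CCC(=O)OCCCOP(=O)(O)OC[C@H](N)C(=O)O`, gives 14.6%.
Compound 2, `N[C@@H](COP(=O)(O)OCCCOC(=O)CCc1ccccc1OCCCCOc1ccccc1)C(=O)O`, gives 6.1%.
Compound 3, `N[C@@H](COP(=O)(O)OCCCOC(=O)CCc1ccccc1OCc1cccc(Cc2ccccc2)c1)C(=O)O`, gives 14.5%.

Compound 3 stands close to the other two: its value and that of compound 1 lie almost on top of each other, and the value of compound 2 is also within the usual scatter of compound 3. For the measured compounds named here, the only step between two compounds differing in a single place is a number 8.5 percentage points lower from compound 1 to compound 2 (within the scatter), and that step concerns the chain attached to the inner aromatic ring, not the outer ring.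

Compound 4, `Cc1ccccc1Oc1cccc(COc2ccccc2CCC(=O)OCCCOP(=O)(O)OC[C@H](N)C(=O)O)c1`, is the next compound to be measured. Compared with compound 3, (2-methylphenoxy in place of benzyl on an aromatic carbon). Going by the values given here, no measured step touches this position, so there is no direct precedent. Among the compounds with values here, the single step available, an aryl ether entering in place of an alkyl chain, stayed within the scatter, and all three measured values are close together. The account therefore expects a number 1.5 percentage points lower from compound 3 to compound 4 (within the scatter), that is, no movement beyond the scatter. Compound 4 is estimated to give 13% in this assay, with a range from 4% to 26%.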

Compound 4, largest response reached (Emax), in percent of the reference or control that the assay uses: 20.3%
Beside the measured number, compound 4's estimate is 7.3 percentage points below it; measured number inside the range.
By their numbers in this assay, from the lowest: compounds 2, 3, 1 and 4 (each within the scatter of the next, the first and the last beyond it).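

In this assay, this is the first change shown at this position, an aromatic carbon meta to a large group, and it gives a number 5.8 percentage points higher from compound 3 to compound 4 (within the scatter). The position therefore takes 2-methylphenoxy in place of benzyl with no movement beyond the scatter, even though the entering group has 8 heavy atoms against 7 and 1 hydrogen-bond acceptor against 0. This single step shows only that the read-out holds across this exchange, and it does not separate the contribution of the methyl group from that of the ether oxygen. No supporting evidence is available to explain the result.

The compounds shown leave open whether plain phenoxy without the methyl group, or a 3-methylphenoxy or 4-methylphenoxy group, would read the same at this position. On these data alone, they also leave open how an amine or a carboxylic acid at this position, or a longer chain in place of the aromatic group, would fare in this assay, so the limits of what the position tolerates remain unknown.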